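The compounds below may be only part of what the source reports. "The series", "measured", "known", "first", "only" and "open" are said of these compounds alone.

Measured so far:
Compound 1 `CCCCNc1nc(N)nc2c1CN(Cc1ccccc1Cl)CC2`: in an assay on HEK293 cells for agonist activity at Toll-like receptor 8 (Homo sapiens), read by a luciferase reporter, with a stated time of 6 h (on this read-out higher numbers stand for an effect only at larger amounts of compound and lower numbers for an effect already at smaller amounts), compound 1 gives 0.05 uM.
Compound 2 `CCCCNc1nc(N)nc2c1CN(C(=O)C1CCC1)CC2`: in this assay compound 2 gives 0.4 uM.

Among the measured compounds shown here, compound 2 holds the higher of the two numbers; the one step, an 8.0-fold higher number from compound 1 to compound 2 (0.90 log units; beyond the scatter), lies beyond the scatter. Compound 3 `CCCCNc1nc(N)nc2c1CN(C(=O)c1csnn1)CC2` keeps the carbonyl of compound 2 and alters the group on it: 1,2,3-thiadiazol-4-yl in place of cyclobutyl on a carbonyl carbon. For the measured compounds named here, no measured step changes a group on a carbonyl carbon; the step already seen swapped the substituent on the amine nitrogen itself and offers no direct guide. Absent such data, no step beyond the scatter is expected for compound 3 in this assay, the expected step being no change at the digits printed from compound 2 to compound 3 (within the scatter). Compound 3 is therefore estimated at 0.4 uM, within 0.1 uM to 1.6 uM.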

Compound 3, minimum effective concentration: 0.1 uM
Beside the measured number, compound 3's estimate is 4.0-fold (0.60 log units) above it, within the range that was stated.
By their numbers in this assay, from the lowest: compounds 1 and 3 (each within the scatter of the next); then compound 2.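

In this assay the group on the carbonyl carbon alone moves the number, with a 4.0-fold lower number from compound 2 to compound 3 (0.60 log units; beyond the scatter) as the first step read at this place. With a 2.0-fold higher number from compound 1 to compound 3 (0.30 log units; within the scatter) in hand, the higher number of compound 2 does not hold for every carbonyl on this amine nitrogen in a ring. Nothing at hand accounts for either step.
From the compounds shown here alone, whether the 1,2,3-thiadiazol-4-yl ring's hetero atoms matter, or any five-membered aromatic ring would do, remains open. A plain phenyl or a furan ring on the same carbonyl carbon would separate these readings.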